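The source may hold more compounds than are shown below. What is called first, only, known or untested is meant among the compounds shown, and "the series" means these compounds.

Compound 1 `CCS[C@@H]1[C@H](SCC)[C@@H](Cn2cc(-c3ccccc3)nn2)O[C@H]1n1ccc(=O)[nH]c1=O` carries a phenyl group on its five-membered aromatic ring. In a functional assay on LAC cells (Homo sapiens) for cytotoxicity, read by MTT assay, with a stated time of 72 h (on this read-out lower numbers stand for an effect already at smaller amounts and higher numbers for an effect only at larger amounts of compound), compound 1 gives "not determined" (no result reported), so it stands without a number. Its close relative compound 2 `CCS[C@@H]1[C@H](SCC)[C@@H](Cn2cc(-c3ccccc3C(F)(F)F)nn2)O[C@H]1n1ccc(=O)[nH]c1=O`, which bears a trifluoromethyl on that phenyl, gives 81100 nM in this assay, an effect only at large amounts. Compound 3 `CCS[C@@H]1[C@H](SCC)[C@@H](Cn2cc(COC(C)=O)nn2)O[C@H]1n1ccc(=O)[nH]c1=O` replaces the phenyl with acetoxymethyl in place of phenyl on an aromatic carbon. With compound 2 the only measured point, a step of only moderate size in this assay is expected, in either direction or none beyond the scatter. Compound 3 is estimated to give 90000 nM, within 30000 nM to 300000 nM.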

Compound 3, half-maximal effective concentration: >= 100000 nM
Compound 3 ended at the assay's limit (the forecaster's own chance of this, stated with the estimate: 35%); middle value at least 1.1-fold (0.04 log units) away from the limit.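

Compound 3 gives >= 100000 nM in this assay, which is a limit of the assay and not a number. Putting acetoxymethyl on this aromatic carbon gives an at least 1.2-fold higher number from compound 2 to compound 3 (0.09 log units; that floor lies within the scatter). So a group with no ring and with hydrogen-bond acceptors brings no effect at smaller amounts here than the aromatic 2-(trifluoromethyl)phenyl group did.

On these data alone, how far compound 3 truly lies from compound 2 stays open, since only a limit is available: the limit of >= 100000 nM in this assay, at which 1 of the 3 values shown sits. Whether an amine or a carboxylic acid on this carbon would bring the effect down to smaller amounts also stays open.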